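One Methyl Removed from the 2,4-Dimethylphenyl Sulfonamide

This account rests on a few compounds, and the source may have more. Where it says the series, first, only, none or still open, it means among the compounds named here.

In a functional assay on HT-29 cells (Homo sapiens) for antiproliferative activity, read by sulforhodamine B assay, with a stated time of 48 h (a lower number here means a stronger inhibitor, a higher number a weaker inhibitor), compound 1 `CCc1cccc(NS(=O)(=O)c2ccc(N3CCNC3=O)cc2)c1` gives 110 nM and compound 2 `Cc1ccc(NS(=O)(=O)c2ccc(N3CCNC3=O)cc2)c(C)c1` gives 180 nM, so compound 2 stands within the scatter of compound 1. Compound 3 `Cc1ccccc1NS(=O)(=O)c1ccc(N2CCNC2=O)cc1` differs from compound 2 by hydrogen in place of methyl on an aromatic carbon, with hydrogen in place of methyl on an aromatic carbon. Among the compounds with values here, the one measured step that bears on this, a 1.6-fold higher number from compound 1 to compound 2 (0.21 log units; within the scatter), also changes the group on the sulfonamide nitrogen and stays small, so no step beyond the scatter is expected in this assay. The estimated change is a 1.2-fold higher number from compound 2 to compound 3 (0.09 log units; within the scatter). For compound 3 the expected value is 220 nM, with an estimated range of 90 nM to 550 nM.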

Compound 3, half-maximal inhibitory concentration: 200 nM
Estimate against measurement, compound 3: 1.1-fold (0.04 log units) above; measured number inside the range.
By their numbers in this assay, from the lowest: compounds 1, 2 and 3 (each within the scatter of the next).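

In this assay, removing the methyl para to a large group, which turns 2,4-dimethylphenyl into 2-methylphenyl, gives a 1.1-fold higher number from compound 2 to compound 3 (0.05 log units; within the scatter), so at this position hydrogen and methyl cannot be told apart. Placing 2-methylphenyl instead of 3-ethylphenyl on the sulfonamide nitrogen gives a 1.8-fold higher number from compound 1 to compound 3 (0.26 log units; within the scatter), so these numbers do not separate the three aryl groups either. Nothing shown here offers an explanation for this result.

As far as these compounds go, whether an amine, a carboxylic acid or a longer chain at this position would move the number beyond the scatter remains open. So does the effect of removing the remaining methyl as well.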